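A few compounds are considered here, and "the series" means these few. Any claim that something is new, unique, unknown or untested is made for them only; others in the source may bear on it.

Measured compounds:
compound 1 `COc1ccc2[nH]c(-c3nc(C)no3)cc2c1`, 19900 nM
compound 2 `Oc1ccc2[nH]c(-c3nc(-c4ccccc4)no3)cc2c1`, 26900 nM

In a functional assay on Jurkat cells (Homo sapiens) for antiproliferative activity, read by WST assay, with a stated time of 72 h (on this read-out lower numbers stand for stronger inhibition and higher numbers for weaker inhibition), compound 2 gives the highest of the two numbers; its nearest neighbour is compound 1, and the two values lie within the scatter of each other, so nothing separates them. Compound 3 `Clc1ccc2[nH]c(-c3nc(-c4ccccc4)no3)cc2c1` is not yet measured. It differs from compound 2 by chloro in place of hydroxy on an aromatic carbon. Among the measured compounds shown here, no measured pair shows this change, so its size is unknown; a small move toward a lower number in this assay is expected, close to the scatter, and the step is estimated as a 1.8-fold lower number from compound 2 to compound 3 (0.25 log units; within the scatter). Compound 3 is expected to give 15000 nM, within 4000 nM to 60000 nM.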

Compound 3, half-maximal inhibitory concentration: > 50000 nM
Compound 3: a limit, no number; the forecaster's own chance of this, stated with the estimate: 15%; middle value at least 3.3-fold (0.52 log units) from the limit.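

In this assay compound 3 gives > 50000 nM, which is a limit of the assay and not a number. Chloro in place of hydroxy on this aromatic carbon gives an at least 1.8-fold higher number from compound 2 to compound 3 (0.26 log units; that floor lies within the scatter), so the change brings no move toward a lower number, though its floor alone cannot separate the two compounds. The true size of the step stays unread, with only a floor to go on: the limit of > 50000 nM in this assay, at which 1 of the 3 values shown sits.

As far as these compounds go, whether an amine or a carboxylic acid on this aromatic carbon would give a lower number remains open. Among the compounds shown here, compound 1 differs from compound 2 in more than one place, so no step between them can be read.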